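Pyridin-4-yl in Place of Phenyl: An Expected Read-out

This account rests on a few compounds, and the source may have more. Where it says the series, first, only, none or still open, it means among the compounds named here.

Of the compounds shown here, two sharing one core have been tested in a functional assay on the whole organism (plasma, strain Wistar) with Rattus norvegicus as the target, with a stated time of 15 days, at a dose of 10 mg/kg by the oral route; on this read-out higher numbers stand for a stronger effect at the one dose given and lower numbers for a weaker effect. Compound 1 `O=C1NC(=O)/C(=C/c2ccc(OCCSc3nnc(-c4ccc(Br)cc4)[nH]3)cc2)S1` gives 20.4% in this assay. Compound 2 `O=C1NC(=O)/C(=C/c2ccc(OCCSc3nnc(-c4ccccc4)o3)cc2)S1` gives 14.6% in this assay. Compound 2 holds the smaller of the two numbers, but its gap to compound 1 lies within the usual scatter of repeated measurements, so the two compounds cannot be told apart on this read-out, and neither can be called the more active.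

Compound 3 `O=C1NC(=O)/C(=C/c2ccc(OCCSc3nnc(-c4ccncc4)o3)cc2)S1` has not yet been measured in this assay. It differs from compound 2 in one place: pyridin-4-yl in place of phenyl on an aromatic carbon. Among the compounds with values here, no measured pair in this set shows what such a change does, so nothing measured points to a gain or a loss.

Within the data shown here, with no comparable step to draw on, the expectation for compound 3 rests on compound 2, which gives 14.6%, and the expected change is a number 1.4 percentage points higher from compound 2 to compound 3 (within the scatter), a step that stays within the scatter rather than a clear move in either direction. Compound 3 is therefore estimated at 16%, with a range from 5% to 30%.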

Compound 3, a percentage reported as activity, at one dose (the size of the read-out at that dose, not a potency): 32.6%
Compound 3: middle estimate off by 16.6 percentage points, on the low side, and the stated range ends below it.
By their numbers in this assay, from the lowest: compounds 2 and 1 (each within the scatter of the next); then compound 3.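

Within the data shown here, this pair is the first in the set to show what a change at this position does: in this assay, pyridin-4-yl in place of phenyl gives a number 18 percentage points higher from compound 2 to compound 3 (beyond the scatter) on the five-membered aromatic ring. The group that leaves and the group that enters both count 6 heavy atoms, and they differ in one ring carbon exchanged for a nitrogen, which the count records as 1 hydrogen-bond acceptor, so an exchange of a single ring atom in this group is enough to move the read-out. Nothing measured here explains how that exchange produces the step.

The compounds shown leave open whether the nitrogen has to sit where it does in pyridin-4-yl, which pyridin-3-yl or pyridin-2-yl at the same carbon would test, and whether a ring with a second nitrogen, such as pyrimidin-5-yl, would read differently again. They also leave open whether the same exchange would give a similar step on the core of compound 1, or whether an amine or a carboxylic acid on the phenyl ring of compound 2 would move the read-out as well.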